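A few compounds are considered here, and "the series" means these few. Any claim that something is new, unique, unknown or untested is made for them only; others in the source may bear on it.

Measured compounds:
Compound 1, `O=C(Nn1c(-c2cccc([N+](=O)[O-])c2)nc2c(-c3ccc(Cl)cc3)n[nH]c2c1=O)c1cccnc1`, in a functional assay on DU-145 cells (Homo sapiens) for cytotoxicity, read by sulforhodamine B assay, with a stated time of 2 days, tested at 100 uM (a higher number here means more inhibition at the concentration tested (going by the name of the read-out), a lower number less inhibition), gives 31%.
Compound 2, `O=C(Nn1c(-c2cccc([N+](=O)[O-])c2)nc2c(-c3ccc(Cl)cc3)n[nH]c2c1=O)c1ccccc1`, in this assay gives 94.3%.

For the measured compounds named here, compound 2 stands highest of the two numbers in this assay; its nearest neighbour is compound 1, and the only measured step runs a number 63.3 percentage points higher from compound 1 to compound 2 (beyond the scatter). Compound 3, `CCCCCc1nc2c(-c3ccc(Cl)cc3)n[nH]c2c(=O)n1NC(=O)c1ccccc1`, differs from compound 2 by pentyl in place of 3-nitrophenyl on an aromatic carbon. Going by the values given here, the one measured step concerns the group on the carbonyl carbon, not the aromatic carbon touched here, so it bears on the new change only as a sign that single-group swaps can move the read-out in this assay a long way. Among the compounds with values here, no measured step alters the group at the aromatic carbon. The expectation is therefore wide: compound 3 is estimated to come in somewhat below compound 2, a step of a number 34.3 percentage points lower from compound 2 to compound 3 (beyond the scatter), landing at 60% with a range from 20% to 95%.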

Compound 3, a percentage reported as inhibition, at one concentration (the size of the read-out at that concentration, not a potency): 88.7%
The estimate for compound 3 lay 28.7 percentage points below the measured number; low and high end bracket the measured number.
By their numbers in this assay, from the lowest: compound 1; then compounds 3 and 2 (each within the scatter of the next).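

At the aromatic carbon between two ring nitrogen atoms, the step in this assay is a number 5.6 percentage points lower from compound 2 to compound 3 (within the scatter) and stays small beside the earlier step on the carbonyl carbon, a number 63.3 percentage points higher from compound 1 to compound 2 (beyond the scatter). With the benzamido group in place, the 3-nitrophenyl ring is therefore not needed for a high reading at the concentration tested, since pentyl, which has no ring, gives a reading that cannot be told apart from it. No measurement shown here accounts for this match between the two groups.

The compounds shown leave open whether a shorter chain such as methyl, or an amine at the end of the pentyl chain, would hold the reading at this position. They also leave open whether pentyl would keep it alongside the pyridin-3-yl carbonyl of compound 1, which gives 31% with 3-nitrophenyl.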